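From Imidazolyl to Methyl: Expected Tolerance of Compound 4

This account rests on a few compounds, and the source may have more. Where it says the series, first, only, none or still open, it means among the compounds named here.

Compound 1 `O=C(/C=C/c1ccc([N+](=O)[O-])s1)c1ccc(-n2ccnc2)cc1` is the starting point of this step. In an ADME assay on THP-1 cells (Homo sapiens) for cytotoxicity, read by resazurin assay, with a stated time of 72 h (a lower number here means that less compound is tolerated, a higher number that more compound is tolerated), compound 1 gives 23400 nM, the lowest of the two numbers reported. Its nearest neighbour is compound 3 `CCCCc1ccc(C(=O)/C=C/c2ccc([N+](=O)[O-])o2)cc1`, which gives 48700 nM in this assay and so sits higher. Compound 2 `O=C(/C=C/c1ccc(Cl)s1)c1ccc(-n2ccnc2)cc1` reaches only a limit in this assay, > 50000 nM. For the measured compounds named here, that limit, (the limit of > 50000 nM in this assay, at which 1 of the 3 values shown sits), caps the one measured single-point step, an at least 2.1-fold higher number from compound 1 to compound 2 (0.32 log units; beyond the scatter), a change at the other end of the molecule.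

Compound 4 `Cc1ccc(C(=O)/C=C/c2ccc([N+](=O)[O-])s2)cc1` differs from compound 1 by methyl in place of 1H-imidazol-1-yl on an aromatic carbon. Going by the values given here, no measured step covers this change: compound 3 differs from compound 1 at two places at once, so its value can only hint that a smaller ring substituent goes with a higher number. On that slender basis a modest rise in this assay is expected, a 1.5-fold higher number from compound 1 to compound 4 (0.17 log units; within the scatter), with a real chance that only a limit is reported. Compound 4 is therefore expected to give about 35000 nM in this assay, with a range from 15000 nM to 60000 nM.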

Compound 4, half-maximal cytotoxic concentration: 13500 nM
The estimate for compound 4 lay 2.6-fold (0.41 log units) above the measured number, and the stated range ends above it.
By their numbers in this assay, from the lowest: compounds 4 and 1 (each within the scatter of the next); then compound 3. At a limit, above all of these: compound 2.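

In this assay, the step at this place reads a 1.7-fold lower number from compound 1 to compound 4 (0.24 log units; within the scatter), so exchanging 1H-imidazol-1-yl for methyl, on an aromatic carbon para to a large group, leaves the number within the scatter. This is the only single change shown at this end of the molecule, and it indicates that replacing a five-membered aromatic ring of 5 heavy atoms with a group of 1 heavy atom does not clearly alter how much compound is tolerated. Nothing shown gives a reason for this result.

On these data alone, whether an amine or a carboxylic acid on the same aromatic carbon would move the number beyond the scatter remains open. Also open, as far as these compounds go, is whether methyl in place of 1H-imidazol-1-yl would behave the same way in compound 2, which carries chloro instead of nitro.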